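A Methoxy Group Joins a Triazole Ether Series

The source may hold more compounds than are shown below. What is called first, only, known or untested is meant among the compounds shown, and "the series" means these compounds.

Of the compounds shown here, three built on one shared core have been tested in a functional assay on U-251 cells (Homo sapiens) for inhibition, read by sulforhodamine B assay, with a stated time of 48 h; a lower number here means a stronger inhibitor of growth, a higher number a weaker inhibitor of growth. Compound 1 `C=C(C)[C@@H]1CC=C(Cn2cc(COc3ccc(C4NC(=O)NC(C)=C4C(=O)OCC)cc3)nn2)CC1` gives 12400 nM in this assay. Compound 2 `C=C(C)[C@@H]1CC=C(Cn2cc(COc3cccc(C4NC(=O)NC(C)=C4C(=O)OCC)c3)nn2)CC1` gives 12200 nM in this assay, the lower of the two numbers shown, though its gap to compound 1 lies within the scatter, so the two cannot be told apart. Compound 3 `C=C(C)[C@@H]1CC=C(Cn2cc(COc3ccccc3C3NC(=O)NC(C)=C3C(=O)OCC)nn2)CC1` returns only a limit in this assay, namely > 100000 nM, which is the limit of > 100000 nM in this assay, at which 1 of the 3 values shown sits.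

Compound 4 `C=C(C)[C@@H]1CC=C(Cn2cc(COc3cc(C4NC(=O)NC(C)=C4C(=O)OCC)ccc3OC)nn2)CC1` has not yet been measured. It differs from compound 2 by methoxy in place of hydrogen on an aromatic carbon. Going by the values given here, no two of the measured compounds differ in only one place, so no measured step shows what this added methoxy does here. The measured compounds differ only in where the ether arm sits on the ring, and compounds 1 and 2 show that two placements give about the same number, while compound 3 sits at a limit.

Among the compounds with values here, with no matching step to lean on, the expected step is a 1.0-fold lower number from compound 2 to compound 4 (0.01 log units; within the scatter), a shift no larger than the scatter. Compound 4 is therefore estimated to give about 12000 nM in this assay, with a likely range from 5000 nM to 30000 nM.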

Compound 4, concentration for total growth inhibition: 98100 nM
Compound 4: the middle estimate sits 8.2-fold (0.91 log units) below what was measured; the measured number lies above the stated range.
By their numbers in this assay, from the lowest: compounds 2 and 1 (each within the scatter of the next); then compound 4. At a limit, above all of these: compound 3.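

In this assay, putting methoxy on the aromatic ring of compound 2, ortho to a large group and para to a large group, gives an 8.0-fold higher number from compound 2 to compound 4 (0.91 log units; beyond the scatter), so this place on the ring does not take the change without cost. Going by these compounds alone, the earlier compounds showed only what happens when the ether arm sits at different places on the ring, whereas this step is the first to show that adding one small group of 2 heavy atoms, with the rest of the molecule unchanged, weakens growth inhibition by more than the scatter. The upper end of the readings is still held by compound 3, which gives a limit and not a number: the limit of > 100000 nM in this assay, at which 1 of the 4 values shown sits.

A single step at a single place cannot say whether the loss belongs to methoxy itself or would follow any group put there, and these numbers give no cause for it. A hydroxyl, a fluorine or a methyl at the same place, or methoxy elsewhere on the ring, would tell those two readings apart.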